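Phenyl Where Bromo Stood: Expecting the Shift

The source may report more compounds than this note shows. Statements on the series, on what has been measured and on what is new or still open speak of the compounds shown alone.

Three compounds have been measured so far in an assay on brain for binding affinity to Neuronal acetylcholine receptor; alpha4/beta2 (Rattus norvegicus), read by radioligand binding; on this read-out higher numbers stand for weaker inhibition and lower numbers for stronger inhibition:
compound 1, `Brc1ccc(OC[C@@H]2CCN2)cn1`, gives 0.021 nM
compound 2, `N#Cc1ccc(OC[C@@H]2CCN2)cn1`, gives 1.9 nM
compound 3, `C=Cc1ccc(OC[C@@H]2CCN2)cn1`, gives 1.25 nM

Compound 1 has the lowest number of the three, and both others lie well beyond the scatter from it: the nearer is a 60-fold higher number from compound 1 to compound 3 (1.77 log units; beyond the scatter), the further is a 90-fold higher number from compound 1 to compound 2 (1.96 log units; beyond the scatter). Between compounds 2 and 3 the difference is a 1.5-fold lower number from compound 2 to compound 3 (0.18 log units; within the scatter), so those two cannot be told apart.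

Compound 4, `c1ccc(-c2ccc(OC[C@@H]3CCN3)cn2)cc1`, is built from compound 1 by one change: phenyl in place of bromo on an aromatic carbon. The two measured steps that bear on this both replace the same bromo on the same aromatic carbon, and both were large losses, a 90-fold higher number from compound 1 to compound 2 (1.96 log units; beyond the scatter) and a 60-fold higher number from compound 1 to compound 3 (1.77 log units; beyond the scatter). Nothing measured suggests a phenyl in this place behaves differently, so a large step toward a higher number is expected for compound 4 as well, a 240-fold higher number from compound 1 to compound 4 (2.38 log units; beyond the scatter). The estimate for compound 4 is therefore 5 nM, with a range from 0.5 nM to 50 nM.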

Compound 4, inhibition constant: 2.3 nM
For compound 4 the middle estimate is 2.2-fold (0.34 log units) above the measured one; low and high end bracket the measured number.
By their numbers in this assay, from the lowest: compound 1; then compounds 3, 2 and 4 (each within the scatter of the next).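

Phenyl brings in a whole ring of its own, yet in this assay it shows a loss of the same large kind as the other replacements, with a 110-fold higher number from compound 1 to compound 4 (2.04 log units; beyond the scatter) as its step away from bromo. Against those replacements there is a 1.8-fold higher number from compound 3 to compound 4 (0.26 log units; within the scatter) and a 1.2-fold higher number from compound 2 to compound 4 (0.08 log units; within the scatter) and so no difference can be read. At this place, on an aromatic carbon next to the ring nitrogen, cyano, vinyl and phenyl thus form one group well apart from bromo, and adding the ring changes nothing that can be read among them.

No evidence is given on why bromo stands apart from these three groups. Going by these compounds, whether another halogen such as chloro or iodo, or an amine, would stay close to compound 1 or fall in with the other three remains open.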